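The compounds below may be only part of what the source reports. "The series", "measured", "known", "first", "only" and "open" are said of these compounds alone.

Compound 1, `COc1ccc(C(=O)Nc2ccccc2SC)cc1OC1CCCC1`, is examined in an assay on isolated protein for inhibition of phosphodiesterase 4A (Sus scrofa) (on this read-out higher numbers stand for weaker inhibition and lower numbers for stronger inhibition), where compound 1 gives 1200 nM. Of the two numbers in hand this is the higher one; the nearer of the two belongs to compound 2, `COc1ccc(C(=O)Nc2ccccc2Cl)cc1OC`, which in this assay gives 650 nM, and the gap between compound 2 and compound 1 falls within the usual scatter of the measurement, so the two are best read as alike. Within the data shown here, no step between measured compounds that differ in one place is available, so the only guide to the next compound is the change itself.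

Compound 3, `COc1ccc(C(=O)Nc2ncccc2C)cc1OC1CCCC1`, shares the core of compound 1 and differs from it in one place: 3-methylpyridin-2-yl in place of 2-(methylsulfanyl)phenyl on an amide-type nitrogen. Nothing in the two measured numbers speaks for or against this exchange, and the account rests on the structural change alone. The step expected for this assay, a 1.5-fold lower number from compound 1 to compound 3 (0.18 log units; within the scatter), is one that would sit within the scatter rather than beyond it, with no clear direction. For compound 3 in this assay the estimate is 800 nM, with a range from 200 nM to 3200 nM.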

Compound 3, half-maximal inhibitory concentration: 3100 nM
The estimate for compound 3 lay 3.9-fold (0.59 log units) below the measured number; the range from low to high includes it.
By their numbers in this assay, from the lowest: compounds 2 and 1 (each within the scatter of the next); then compound 3.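

In this assay, the exchange of 2-(methylsulfanyl)phenyl for 3-methylpyridin-2-yl on an amide-type nitrogen whose other neighbour is the carbonyl carbon gives a 2.6-fold higher number from compound 1 to compound 3 (0.41 log units; beyond the scatter) and so moves the number beyond the scatter, though only modestly. Among these compounds, this is the first sign that the group at this position matters to the read-out, since compound 1 and compound 3 share the rest of their structure. The two groups have the same counts of hydrogen-bond donors and acceptors and neither carries a net charge, so these counts do not separate compound 1 from compound 3, and nothing measured here speaks to the cause of the step.

The exchange alters the ring and its substituent together, so the compounds shown leave open whether the step follows the ring nitrogen, the loss of the methylsulfanyl group, or both. A 2-methylphenyl group or an unsubstituted pyridin-2-yl group at this position would begin to pull these apart, and a methoxy group in place of the methylsulfanyl group would test how much that sulfur atom contributes.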